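The source may hold more compounds than are shown below. What is called first, only, known or untested is meant among the compounds shown, and "the series" means these compounds.

Measured so far in a functional assay on MCF7 cells (Homo sapiens) for antiproliferative activity, read by MTT assay, with a stated time of 48 h; a lower number here means a stronger inhibitor, a higher number a weaker inhibitor:
- compound 1 (`Fc1ccc(-c2nn(-c3ccccc3)cc2-c2nc3cc(F)ccc3[nH]2)cc1`) gives 950 nM
- compound 2 (`Cc1ccc2[nH]c(-c3cn(-c4ccccc4)nc3-c3ccc(F)cc3)nc2c1`) gives 1120 nM
- compound 3 (`Cc1cc2nc(-c3cn(-c4ccccc4)nc3-c3ccc(F)cc3)[nH]c2cc1C`) gives 27200 nM

In this assay compound 2 has one close neighbour and one distant one: the first gap is a 1.2-fold higher number from compound 1 to compound 2 (0.07 log units; within the scatter), and the second is a 24-fold higher number from compound 2 to compound 3 (1.39 log units; beyond the scatter).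

The unmeasured compound 4 (`COc1ccc(-c2nn(-c3ccccc3)cc2-c2nc3cc(C)ccc3[nH]2)cc1`) differs from compound 2 in a single place: methoxy in place of fluoro on an aromatic carbon. The change turns 4-fluorophenyl into 4-methoxyphenyl, para to a large group.

For the measured compounds named here, no measured step touches this group, so the evidence is indirect. The closest in kind is the swap of fluoro for methyl, a 1.2-fold higher number from compound 1 to compound 2 (0.07 log units; within the scatter), which points to little change. The methyl added in place of hydrogen, a 24-fold higher number from compound 2 to compound 3 (1.39 log units; beyond the scatter), is a warning that one small change on an aromatic carbon can go with a large jump, so the upper range is kept wide.

The expected result is a 1.3-fold higher number from compound 2 to compound 4 (0.13 log units; within the scatter), with no shift beyond the scatter anticipated. For compound 4 the estimate is 1500 nM, with an expected range from 450 nM to 6000 nM.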

Compound 4, half-maximal inhibitory concentration: 6610 nM
For compound 4 the middle estimate is 4.4-fold (0.64 log units) below the measured one, and the stated range ends below it.
By their numbers in this assay, from the lowest: compounds 1 and 2 (each within the scatter of the next); then compound 4; then compound 3.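

In this assay, putting methoxy in place of fluoro on the 4-fluorophenyl group gives a step beyond the scatter (a 5.9-fold higher number from compound 2 to compound 4 (0.77 log units; beyond the scatter)), so this position is not indifferent to what it carries. For the compounds shown here, this is the first measured change at this group, and it shows that the swap to 4-methoxyphenyl weakens the compound without abolishing its activity. Nothing in the data ties this step to a particular property of either group, so its cause stays unknown.

The compounds shown leave open how a chlorine, a hydroxyl or an amine at this position would read, and whether ethoxy, a longer chain on the same oxygen, would widen the step. They also leave open whether the same swap would give a step of similar size on the core of compound 1 or compound 3.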